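Aryl change on the carbon double-bonded to nitrogen

The source may hold more compounds than are shown below. What is called first, only, known or untested is meant among the compounds shown, and "the series" means these compounds.

Measured so far:
compound 1 `COc1cc2c(Oc3ccc(NC(=O)N/N=C/c4ccc(Cl)cc4Cl)cc3F)ccnc2cc1OCCCN1CCCCC1` — 370 nM
compound 2 `COc1cc2c(Oc3ccc(NC(=O)N/N=C/c4ccc(N(C)C)cc4)cc3F)ccnc2cc1OCCCN1CCCCC1` — 1000 nM

In a functional assay on HT-29 cells (Homo sapiens) for cytotoxicity, read by MTT assay, with a stated time of 72 h (a higher number here means a weaker inhibitor, a lower number a stronger inhibitor), compound 1 gives 370 nM, the lowest of the two numbers in hand. The nearest is compound 2, which in this assay gives 1000 nM. Among the compounds with values here, that pair is the only measured step: a 2.7-fold higher number from compound 1 to compound 2 (0.43 log units; beyond the scatter).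

Compound 3 `COc1cc2c(Oc3ccc(NC(=O)N/N=C/c4cccs4)cc3F)ccnc2cc1OCCCN1CCCCC1` is not yet measured. It differs from compound 1 at the same position that was varied before: thiophen-2-yl in place of 2,4-dichlorophenyl on a carbon with a double bond to nitrogen. Within the data shown here, the single step that bears on it shows that swapping the aryl on that carbon moved the number by a modest amount toward weaker inhibition, with no example so far of a swap there that strengthened it. A step of similar size, in the same direction, is therefore expected in this assay.

Compound 3 is estimated at 700 nM, with a range of 250 nM to 2000 nM, which would mean an expected 1.9-fold higher number from compound 1 to compound 3 (0.28 log units; within the scatter).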

Compound 3, half-maximal inhibitory concentration: 770 nM
Compound 3: the middle estimate sits 1.1-fold (0.04 log units) below what was measured; the measured number falls inside the stated range.
By their numbers in this assay, from the lowest: compound 1; then compounds 3 and 2 (each within the scatter of the next).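

In this assay the thiophen-2-yl in place of 2,4-dichlorophenyl gives a 2.1-fold higher number from compound 1 to compound 3 (0.32 log units; beyond the scatter), so a second swap on the carbon with a double bond to nitrogen also ends on the weaker side of compound 1, here with a five-membered ring carrying sulfur and no chlorine. The two replacements are not separated by this assay: a 1.3-fold lower number from compound 2 to compound 3 (0.11 log units; within the scatter), so compound 1 alone stands apart among the three. No measurement at hand accounts for that gap.

As far as these compounds go, it remains open whether the gain belongs to the chlorine atoms themselves, which a 4-chlorophenyl or an unsubstituted phenyl on this carbon would test. From the compounds shown here alone, whether a 2,4-difluorophenyl, a pyridin-3-yl or a furan-2-yl could match or pass compound 1 also remains open.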